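Halogenated aryl exchange on one arm of the shared core

The source may hold more compounds than are shown below. What is called first, only, known or untested is meant among the compounds shown, and "the series" means these compounds.

Measured so far:
- compound 1 `COc1cccc(/C=C2\CCC/C(=C\c3cc(OC)c(OC)c(OC)c3)C2=O)c1OC` gives 2300 nM in a functional assay on HT-1080 cells (Homo sapiens) for cytotoxicity, read by MTT assay, with a stated time of 72 h; a lower number here means a stronger inhibitor, a higher number a weaker inhibitor
- compound 2 `COc1ccc(/C=C2\CCC/C(=C\c3cccc(Br)c3)C2=O)cc1OC` gives 5200 nM in this assay

Compound 2 stands with the highest number of the two; compound 1 comes nearest, with a lower number whose gap to compound 2 lies beyond the usual scatter. For the measured compounds named here, only these two numbers exist, and they differ in more than one place, so no single step between measured compounds can be isolated.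

Compound 3 `COc1ccc(/C=C2\CCC/C(=C\c3cccc(Cl)c3Cl)C2=O)cc1OC` is not yet measured. It differs from compound 2 in one place: 2,3-dichlorophenyl in place of 3-bromophenyl on a double-bonded chain carbon bound to a double-bonded ring carbon. One halogen-bearing aryl group gives way to another, with no change in donors, acceptors or charge.

Going by the values given here, with no measured step of this kind to lean on, the expectation rests on the closeness of the two groups: a small step in this assay, if any, leaning toward a lower number, most likely within the scatter. The expected step is a 1.3-fold lower number from compound 2 to compound 3 (0.11 log units; within the scatter). Compound 3 is estimated at 4000 nM, with a range from 1500 nM to 11000 nM.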

Compound 3, half-maximal inhibitory concentration: 8800 nM
The estimate for compound 3 lay 2.2-fold (0.34 log units) below the measured number, and the stated range covers the measured number.
By their numbers in this assay, from the lowest: compound 1; then compounds 2 and 3 (each within the scatter of the next).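

Working notes on the series: at the double-bonded chain carbon bound to a double-bonded ring carbon, the first readable step in this assay is 2,3-dichlorophenyl in place of 3-bromophenyl, and it gives a 1.7-fold higher number from compound 2 to compound 3 (0.23 log units; within the scatter) as its full effect on the read-out. This position therefore accepts an exchange of one halogen-bearing aryl group for another, here two chlorine atoms for one bromine atom and one more heavy atom overall, without a separation beyond the usual scatter, which the two earlier compounds could not show because they differ in more than one place. Nothing measured here bears on why the two groups read so alike.

Compound 1 still differs from the other two compounds in more than one place, so its steps to them cannot be read, and the contribution of each arm to its number stays unresolved. The compounds shown also leave open how this position responds to aryl groups without halogen, such as a phenyl ring bearing an amine or a carboxylic acid, and whether a pyridine ring would fit in place of the halogenated phenyl.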